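A few compounds are considered here, and "the series" means these few. Any claim that something is new, unique, unknown or untested is made for them only; others in the source may bear on it.

Compound 3 `O=C(NCc1cn(Cc2ccc(Cl)cc2)nn1)c1cn(-c2ccccc2)nc1-c1ccc(F)cc1` gives 130 nM in a functional assay on MCF7 cells (Homo sapiens) for antiproliferative activity, read by sulforhodamine B assay, with a stated time of 48 h (a higher number here means a weaker inhibitor of growth, a lower number a stronger inhibitor of growth), and stands lowest of the two numbers in hand. Compound 2 `COc1cc(Cn2cc(CNC(=O)c3cn(-c4ccccc4)nc3-c3ccccc3)nn2)cc(OC)c1` gives 2400 nM in this assay. Compound 1 `O=C(NCc1cn(Cc2ccc(Cl)cc2)nn1)c1cn(-c2ccccc2)nc1-c1ccccc1` returns only a limit of the assay in this assay, > 100000 nM; the limit of > 100000 nM in this assay, at which 1 of the 3 values shown sits, is where that reading sits. Two steps lead away from compound 1: an at least 41-fold lower number from compound 1 to compound 2 (1.61 log units; beyond the scatter), and an at least 760-fold lower number from compound 1 to compound 3 (2.88 log units; beyond the scatter). Both begin at a limit, so their true size is open-ended.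

Compound 4 `COc1cc(Cn2cc(CNC(=O)c3cn(-c4ccccc4)nc3-c3ccc(F)cc3)nn2)cc(OC)c1OC` is not yet measured. Against compound 3 the change is 3,4,5-trimethoxyphenyl in place of 4-chlorophenyl on a saturated chain carbon bound to an aromatic nitrogen. For the measured compounds named here, the one precedent is an at least 41-fold lower number from compound 1 to compound 2 (1.61 log units; beyond the scatter), the same kind of exchange of the aryl group on that carbon, though with a 3,5-dimethoxyphenyl rather than a 3,4,5-trimethoxyphenyl and without the fluoro on the other ring. That step was large but its lower bound is all that is known, so a lower number than compound 3 is expected in this assay for compound 4, of a size that cannot be fixed from the data; a result within the scatter of compound 3 would not be surprising either. Compound 4 is estimated at 60 nM, with a range from 10 nM to 400 nM. The expected step is a 2.2-fold lower number from compound 3 to compound 4 (0.34 log units; beyond the scatter).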

Compound 4, concentration for 50% growth inhibition: 4300 nM
The estimate for compound 4 lay 72-fold (1.86 log units) below the measured number; measured number above the stated range.
By their numbers in this assay, from the lowest: compound 3; then compounds 2 and 4 (each within the scatter of the next). At a limit, above all of these: compound 1.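

Compound 3 carries the fluoro and the 4-chlorophenyl, and against it the 3,4,5-trimethoxyphenyl on the saturated chain carbon bound to an aromatic nitrogen gives a clear loss in this assay: a 33-fold higher number from compound 3 to compound 4 (1.52 log units; beyond the scatter). The earlier exchange of aryl groups at this place ran the other way, an at least 41-fold lower number from compound 1 to compound 2 (1.61 log units; beyond the scatter), and that step starts at a limit, so the two pairs together show that this place has no single direction for replacing the 4-chlorophenyl with a methoxy-bearing phenyl. The result therefore ties the reading at this place to the rest of the molecule or to the exact substitution of the entering ring, and no measured property among the data shown accounts for the reversal.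

Still open is whether the reversal follows the fluoro on the aromatic carbon or the third methoxy, since no pair among the compounds shown separates the two. Also open, on these data alone, is how a different kind of group at this place, such as an amine, a carboxylic acid or a longer chain in place of the aryl group, would read in this assay.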